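The source may hold more compounds than are shown below. What is called first, only, known or untested is meant among the compounds shown, and "the series" means these compounds.

Of the compounds shown here, three of the shared core have been measured in a functional assay on A549 cells (Homo sapiens) for cytotoxicity, read by MTT assay, with a stated time of 72 h; on this read-out lower numbers stand for an effect already at smaller amounts and higher numbers for an effect only at larger amounts of compound. Compound 1 `CCOc1c(-c2occ(C)c2C(=O)O)ccc2c(CC)cccc12` carries a carboxy on an aromatic carbon. In this assay compound 1 gives only a limit, > 10 ug/mL. Compound 2 `CCOc1c(-c2occ(C)c2C(=O)OC)ccc2c(CC)cccc12` is its methyl ester, and in this assay compound 2 gives 2.4 ug/mL, the step being an at least 4.1-fold lower number from compound 1 to compound 2 (0.61 log units; beyond the scatter). Compound 3 `CCOc1c(-c2occ(C)c2COC)ccc2c(CC)cccc12` carries a methoxymethyl on the aromatic carbon instead. In this assay compound 3 gives only a limit, > 10 ug/mL. Two of the three values sit at the limit of > 10 ug/mL in this assay, at which 2 of the 3 values shown sit, so compound 3 stands with compound 1 and well away from compound 2, as an at least 4.1-fold higher number from compound 2 to compound 3 (0.61 log units; beyond the scatter) shows; the step that the two limits leave unreadable from compound 1 to compound 3 cannot be read.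

Compound 4 `CCOc1c(-c2occ(C)c2COC(C)=O)ccc2c(CC)cccc12` differs from compound 3 by acetyl in place of methyl on an oxygen on a saturated carbon. The measured steps that bear on this are an at least 4.1-fold lower number from compound 1 to compound 2 (0.61 log units; beyond the scatter) and an at least 4.1-fold higher number from compound 2 to compound 3 (0.61 log units; beyond the scatter), both at least modest, and both separate the ester of compound 2 from groups without that carbonyl. Since the acetyl brings a carbonyl back, a modest lowering an at least 1.6-fold lower number from compound 3 to compound 4 (0.22 log units; that floor lies within the scatter) is expected, with wide uncertainty because compound 3 shows only > 10 ug/mL. Compound 4 is estimated at 6 ug/mL, between 2 ug/mL and 15 ug/mL.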

Compound 4, concentration for half-maximal effect: > 10 ug/mL
Compound 4 ended at the assay's limit; the forecaster's own chance of this, stated with the estimate: 40%; middle value at least 1.6-fold (0.22 log units) away from the limit.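

Compound 4 gives only a limit, > 10 ug/mL. At this position a carbonyl in the side group is not enough on its own to keep the value of the methyl ester: acetoxymethyl in place of methoxycarbonyl on the aromatic carbon gives an at least 4.1-fold higher number from compound 2 to compound 4 (0.61 log units; beyond the scatter), and among the compounds shown only compound 2 lies clear of the limit. The steps from compound 3 to compound 4 and from compound 1 to compound 4 cannot be read, because these compounds all sit at one limit: the limit of > 10 ug/mL in this assay, at which 3 of the 4 values shown sit.

As far as these compounds go, how far compound 1, compound 3 and compound 4 lie apart stays open. Also open, from the compounds shown here alone, is whether an amide or an ethyl ester in place of the methyl ester would keep a value near that of compound 2.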